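Amide substituent change on a pyrrolidine sulfonamide scaffold

The source may hold more compounds than are shown below. What is called first, only, known or untested is meant among the compounds shown, and "the series" means these compounds.

Compound 1, `Cc1ccc2[nH]c(C(=O)N[C@H]3CN(S(=O)(=O)c4ccccc4)C[C@@H]3C(=O)NCCN(C)C)cc2c1`, gives 16 uL/min in an ADME assay on cells (Hepatocyte, Rattus norvegicus) for metabolic stability (on this read-out higher numbers stand for fast clearance and lower numbers for slow clearance), the higher of the two numbers measured. Going by the values given here, compound 2, `Cc1ccc2[nH]c(C(=O)N[C@H]3CN(S(=O)(=O)c4ccnc(C)c4)C[C@@H]3C(=O)NCCN(C)C)cc2c1`, gives 8 uL/min in this assay, and the one measured step, a 2.0-fold lower number from compound 1 to compound 2 (0.30 log units; within the scatter), lies within the scatter. Compound 3, `Cc1ccc2[nH]c(C(=O)N[C@H]3CN(S(=O)(=O)c4ccccc4)C[C@@H]3C(=O)N[C@@H]3CCCNC3)cc2c1`, has not yet been measured; it differs from compound 1 only at the amide-type nitrogen whose other neighbour is the carbonyl carbon: piperidin-3-yl in place of 2-(dimethylamino)ethyl on an amide-type nitrogen. Among the compounds with values here, no measured step touches this position, since the step from compound 1 to compound 2 concerns the group on the sulfonyl sulfur and not the amide. Within the data shown here, the data therefore give no direct guide to the size or direction of the change in this assay for compound 3, and the only measured step being within the scatter suggests that the shared core tolerates small changes without large movement. Compound 3 is accordingly expected to sit near compound 1, with the step of a 1.1-fold lower number from compound 1 to compound 3 (0.06 log units; within the scatter) estimated as none beyond the scatter, and its value is estimated at 14 uL/min, within a range of 5 uL/min to 40 uL/min.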

Compound 3, intrinsic clearance in a liver preparation (reported as CLH), per the amount of preparation that the assay uses: 9 uL/min
Compound 3: middle estimate off by 1.6-fold (0.19 log units), on the high side; the range from low to high includes it.
By their numbers in this assay, from the lowest: compounds 2, 3 and 1 (each within the scatter of the next).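

With this result, the amide-type nitrogen has its first measured step in this assay: a 1.8-fold lower number from compound 1 to compound 3 (0.25 log units; within the scatter). Replacing the open-chain 2-(dimethylamino)ethyl with piperidin-3-yl brings in a six-membered non-aromatic ring, a hydrogen-bond donor and a defined stereocentre, yet the step does not exceed the scatter, so this single change gives no sign that the read-out depends on the group at this position. No measurement shown bears on how either group acts in this assay, so the result stays an observation without an explanation.

As far as these compounds go, what a group of a different kind would do on this amide-type nitrogen remains open, whether a cyclohexyl ring with no nitrogen, a longer chain ending in a dimethylamino group, or a carboxylic acid, and any of these might yet give a step beyond the scatter. Also open, from the compounds shown here alone, are the mirror-image arrangement at the stereocentre of the piperidin-3-yl group and the outcome of joining that group with the 2-methylpyridin-4-yl group on the sulfonyl sulfur in one compound.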